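The source may hold more compounds than are shown below. What is called first, only, known or untested is meant among the compounds shown, and "the series" means these compounds.

Three compounds share one core and differ in a single group. Compound 1 `CCCCOC(=O)NS(=O)(=O)c1sc(CC(C)C)cc1-c1ccc(C(=O)c2cccs2)cc1` gives 18.8 nM in an assay on membranes from uterus for displacement of a labelled ligand from Angiotensin type II receptor (Sus scrofa), with a stated time of 1.5 h; a lower number here means a stronger inhibitor, a higher number a weaker inhibitor. Compound 2 `CCCCOC(=O)NS(=O)(=O)c1sc(CC(C)C)cc1-c1ccc(CN2CCN(C)C2=O)cc1` gives 16.5 nM in this assay, and the two lie within the scatter of each other: a 1.1-fold lower number from compound 1 to compound 2 (0.06 log units; within the scatter). Compound 3 `CCCCOC(=O)NS(=O)(=O)c1sc(CC(C)C)cc1-c1ccc(Cn2cnc(C(F)(F)F)c2)cc1` gives 7.3 nM in this assay, the lowest of the three numbers, with modest steps from both others: a 2.6-fold lower number from compound 1 to compound 3 (0.41 log units; beyond the scatter) and a 2.3-fold lower number from compound 2 to compound 3 (0.35 log units; beyond the scatter).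

Compound 4 `CCCCOC(=O)NS(=O)(=O)c1sc(CC(C)C)cc1-c1ccc(Cn2ncnn2)cc1` has not been measured. It differs from compound 3 as follows: 2H-tetrazol-2-yl in place of 4-(trifluoromethyl)-1H-imidazol-1-yl on a saturated chain carbon bound to an aromatic carbon. The step that bears on it most closely is a 2.3-fold lower number from compound 2 to compound 3 (0.35 log units; beyond the scatter), which exchanged the group at the same place for a modest gain; the other exchanges at this part of the molecule, a 1.1-fold lower number from compound 1 to compound 2 (0.06 log units; within the scatter) and a 2.6-fold lower number from compound 1 to compound 3 (0.41 log units; beyond the scatter), were within the scatter or modest. The change to compound 4 keeps a five-membered aromatic ring, so only a small step is expected, more likely toward a somewhat higher number: a 1.6-fold higher number from compound 3 to compound 4 (0.22 log units; within the scatter). Compound 4 is therefore expected to give 12 nM in this assay, with a range from 5 nM to 30 nM.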

Compound 4, inhibition constant: 16 nM
Beside the measured number, compound 4's estimate is 1.3-fold (0.12 log units) below it, and the stated range covers the measured number.
By their numbers in this assay, from the lowest: compound 3; then compounds 4, 2 and 1 (each within the scatter of the next).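

Replacing 4-(trifluoromethyl)-1H-imidazol-1-yl with 2H-tetrazol-2-yl on the saturated chain carbon gives a modest step (a 2.2-fold higher number from compound 3 to compound 4 (0.34 log units; beyond the scatter)), so in this assay a five-membered aromatic ring at this place is not enough on its own to keep the number of compound 3. Among these compounds, the new group instead falls within the scatter of the groups in the two other compounds (a 1.0-fold lower number from compound 2 to compound 4 (0.01 log units; within the scatter); a 1.2-fold lower number from compound 1 to compound 4 (0.07 log units; within the scatter)), which leaves 4-(trifluoromethyl)-1H-imidazol-1-yl as the only group of the four that stands apart. No measurement is available that could account for this difference.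

On these data alone, it remains open whether the lower number of compound 3 goes with the trifluoromethyl group or with the imidazole ring. An unsubstituted 1H-imidazol-1-yl group and a tetrazole ring carrying trifluoromethyl, each at this place, would help separate the two.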